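The compounds below may be only part of what the source reports. "The series", "measured", "known", "first", "only" and "open" are said of these compounds alone.

Among the compounds with values here, in an assay on isolated protein for inhibition of DNA topoisomerase 1 (Homo sapiens), with a stated time of 30 min, tested at 100 uM (a higher number here means a stronger effect of the compound at the concentration tested, a lower number a weaker effect), compound 2 `COc1ccc(/C=C/C(=O)c2ccc(NC(=O)CN3CCN(c4cc5c(cc4F)c(=O)c(C(=O)O)cn5C4CC4)CC3)cc2)cc1` gives 67.6%, the higher of the two numbers so far, while compound 1 `O=C(CN1CCN(c2cc3c(cc2F)c(=O)c(C(=O)O)cn3C2CC2)CC1)Nc1ccc(C(=O)/C=C/c2ccccc2)cc1` gives 57.2%. Within the data shown here, the one measured step, a number 10.4 percentage points higher from compound 1 to compound 2 (beyond the scatter), rests on a methoxy in place of hydrogen on an aromatic carbon. Compound 3 `O=C(CN1CCN(c2cc3c(cc2F)c(=O)c(C(=O)O)cn3C2CC2)CC1)Nc1ccc(C(=O)/C=C/c2cccc([N+](=O)[O-])c2)cc1` differs from compound 2 by 3-nitrophenyl in place of 4-methoxyphenyl on a double-bonded chain carbon bound to a double-bonded chain carbon. That measured step bears on the change only in that it shows the methoxy-bearing 4-methoxyphenyl to be worth a modest gain over the bare phenyl of compound 1 in this assay; nothing measured speaks to a 3-nitrophenyl. Going by these compounds, removing the methoxy alone would be expected to hand back roughly that gain, and what the nitro group adds is unknown, so the step is estimated as a number 9.6 percentage points lower from compound 2 to compound 3 (within the scatter), a modest fall or none beyond the scatter. Compound 3 is therefore expected to give about 58%, within a range of 42% to 74%.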

Compound 3, a percentage reported as inhibition, at one concentration (the size of the read-out at that concentration, not a potency): 90.5%
For compound 3 the middle estimate is 32.5 percentage points below the measured one, outside the stated range (above it).
By their numbers in this assay, from the lowest: compound 1; then compound 2; then compound 3.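

At this place, on a double-bonded chain carbon bound to a double-bonded chain carbon, the aryl group can move this assay much further than the methoxy step showed: a number 33.3 percentage points higher from compound 1 to compound 3 (beyond the scatter) is a large step, where a number 10.4 percentage points higher from compound 1 to compound 2 (beyond the scatter) was a modest one. Substitution on the phenyl thus raises the number in both cases, and the two groups are not interchangeable, with a number 22.9 percentage points higher from compound 2 to compound 3 (beyond the scatter) in the exchange of 4-methoxyphenyl for 3-nitrophenyl. Nothing available explains why the 3-nitrophenyl gives the higher number.

The exchange changes both the group and where it sits on the phenyl ring, so the compounds shown do not separate the nitro group from its placement. Going by these compounds, how a nitrile or an amine on that phenyl would compare also remains open.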